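Chloromethyl for tert-butyl on the amide of compound 3

The source may hold more compounds than are shown below. What is called first, only, known or untested is meant among the compounds shown, and "the series" means these compounds.

Measured so far:
compound 1 `CC(=O)Nc1cccc(S(=O)(=O)Oc2ccccc2C(C)C)c1`, 21000 nM
compound 2 `CCCC(=O)Nc1cccc(S(=O)(=O)Oc2ccccc2C(C)C)c1`, 9400 nM
compound 3 `CC(C)c1ccccc1OS(=O)(=O)c1cccc(NC(=O)C(C)(C)C)c1`, 14000 nM

In a functional assay on MCF7 cells (Homo sapiens) for antiproliferative activity, read by sulforhodamine B assay, with a stated time of 48 h (a higher number here means a weaker inhibitor, a lower number a stronger inhibitor), compound 3 stands second highest of the three numbers, between compound 1 and compound 2, with both neighbours within the scatter of it. Compound 4 `CC(C)c1ccccc1OS(=O)(=O)c1cccc(NC(=O)CCl)c1` differs from compound 3 by chloromethyl in place of tert-butyl on a carbonyl carbon. The measured steps at the same place were small: a 2.2-fold lower number from compound 1 to compound 2 (0.35 log units; beyond the scatter), a 1.5-fold lower number from compound 1 to compound 3 (0.18 log units; within the scatter) and a 1.5-fold higher number from compound 2 to compound 3 (0.17 log units; within the scatter). Changing the group on this carbonyl carbon has so far moved this assay little, so no step beyond the scatter is expected, and compound 4 is estimated near compound 3, at 12000 nM (range 5000 nM to 30000 nM), an expected step of a 1.2-fold lower number from compound 3 to compound 4 (0.07 log units; within the scatter).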

Compound 4, half-maximal inhibitory concentration: 2200 nM
Beside the measured number, compound 4's estimate is 5.5-fold (0.74 log units) above it; measured number below the stated range.
By their numbers in this assay, from the lowest: compound 4; then compounds 2, 3 and 1 (each within the scatter of the next, the first and the last beyond it).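

In this assay, a 6.4-fold lower number from compound 3 to compound 4 (0.80 log units; beyond the scatter) and a 4.3-fold lower number from compound 2 to compound 4 (0.63 log units; beyond the scatter) and a 9.5-fold lower number from compound 1 to compound 4 (0.98 log units; beyond the scatter) all lie beyond the scatter, so compound 4 has the lowest number of the four. This carbonyl carbon therefore responds more strongly than the methyl, propyl and tert-butyl groups suggested, and a single chlorine in place of hydrogen on the methyl group is enough to produce the largest step. Nothing measured here explains this result.

The compounds shown leave open whether bromomethyl or fluoromethyl would give a similar number. They also leave open whether a longer chain such as chloroethyl would keep it.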